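The source may report more compounds than this note shows. Statements on the series, on what has been measured and on what is new or still open speak of the compounds shown alone.

In an ADME assay on HEK-293T cells (Homo sapiens) for inhibition, read by CCK-8 assay, with a stated time of 48 h, tested at 20 uM (on this read-out lower numbers stand for less inhibition of growth and higher numbers for more inhibition of growth at the one concentration tested), compound 3 (`N#C/C(=C\c1ccccc1OS(=O)(=O)c1ccc(Cl)cc1)C(=O)Nc1nnc(-c2cccc(F)c2)s1`) gives 29% and lies within the scatter of compound 1 (`COc1ccc(Cc2nnc(NC(=O)/C(C#N)=C/c3ccccc3OS(=O)(=O)c3ccc(Cl)cc3)s2)cc1`) with its 34% of growth inhibition. Compound 3 lies clearly above compound 2 (`N#C/C(=C\c1ccccc1OS(=O)(=O)c1ccc(F)cc1)C(=O)Nc1nnc(Cc2cccc3ccccc23)s1`) with its 15% of growth inhibition. Compound 4 (`Cc1ccc(Cc2nnc(NC(=O)/C(C#N)=C/c3ccccc3OS(=O)(=O)c3ccc(Cl)cc3)s2)cc1`) is not yet measured. It has 4-methylbenzyl in place of 3-fluorophenyl on an aromatic carbon. For the measured compounds named here, the only measured step at that place is small (a number 5 percentage points lower from compound 1 to compound 3 (within the scatter)) and also involves 3-fluorophenyl and a benzyl group, 4-methoxybenzyl. Going by the values given here, compound 2 differs from compound 3 in more than one place, so it offers no clean step, though it widens the range. No step beyond the scatter is therefore expected in this assay for this change. The estimated change (a number 2 percentage points higher from compound 3 to compound 4 (within the scatter)) stays within that scatter. Compound 4 is expected at 31% with 18% to 45% as its estimated range.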

Compound 4, percent growth inhibition at one concentration: 8%
The estimate for compound 4 lay 23 percentage points above the measured number; measured number below the stated range.
By their numbers in this assay, from the lowest: compounds 4 and 2 (each within the scatter of the next); then compounds 3 and 1 (each within the scatter of the next).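

This position on the shared core is more sensitive than the earlier small step suggested, with a number 21 percentage points lower from compound 3 to compound 4 (beyond the scatter) in growth inhibition. A benzyl group as such does not fix the number, as methyl in place of methoxy on its ring gives a number 26 percentage points lower from compound 1 to compound 4 (beyond the scatter) while the rest of the molecule stays the same. Nothing measured here accounts for this drop.

Open, from the compounds shown here alone, is how a hydroxyl or an amine in place of that methyl would read in this test. Also open, going by these compounds, is whether a longer chain between the core and the ring would shift the number.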